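Lengthening the chain on the thiourea nitrogen: compound 3

The source may hold more compounds than are shown below. What is called first, only, known or untested is meant among the compounds shown, and "the series" means these compounds.

Of the compounds shown here, two sharing one core have been measured in a functional assay on Cortex (Rattus norvegicus, strain Sprague-Dawley), read by LDH release; a lower number here means that less compound is needed, a higher number that more compound is needed for the effect. Compound 1, `CCNC(=S)Nc1nc2ccc(OC(F)(F)F)cc2s1`, gives 0.1 uM in this assay. Within the data shown here, compound 2, `CC(C)NC(=S)Nc1nc2ccc(OC(F)(F)F)cc2s1`, gives 0.01 uM in this assay, the lowest of the two numbers; the only other number, that of compound 1, is higher, and the step of a 10-fold lower number from compound 1 to compound 2 (1.00 log units; beyond the scatter) lies beyond the scatter.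

Compound 3, `CCCCNC(=S)Nc1nc2ccc(OC(F)(F)F)cc2s1`, is the next compound to be measured. Its difference from compound 2 is butyl in place of isopropyl on an amide-type nitrogen. Among the measured compounds shown here, the only measured step touches the same place on the molecule, and it was a 10-fold lower number from compound 1 to compound 2 (1.00 log units; beyond the scatter); it shows that the group on this nitrogen matters for this assay, but it compares a shorter chain with a branched one, not a branched group with a longer straight chain, so it gives the direction of the present change only loosely.

Weighing that one step, compound 3 is expected to give roughly 0.03 uM in this assay, within a range of 0.005 uM to 0.2 uM. That estimate means a step of a 3.0-fold higher number from compound 2 to compound 3 (0.48 log units; beyond the scatter), expected to stay close to the scatter.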

Compound 3, minimum effective concentration: 0.01 uM
Beside the measured number, compound 3's estimate is 3.0-fold (0.48 log units) above it, within the range that was stated.
By their numbers in this assay, from the lowest: compounds 2 and 3 (each within the scatter of the next); then compound 1.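

In this assay, butyl in place of isopropyl gives no change at the digits printed from compound 2 to compound 3 (within the scatter) and so the straight chain of compound 3 and the branched group of compound 2 cannot be told apart here, which means that a branched group is not needed on this nitrogen for a number this low. Going from the ethyl chain of compound 1 to the butyl chain gives a 10-fold lower number from compound 1 to compound 3 (1.00 log units; beyond the scatter) and matches a 10-fold lower number from compound 1 to compound 2 (1.00 log units; beyond the scatter) in size, so among these three compounds ethyl is the only group that stands apart, while two different larger groups give the same number. No measurement is available that could explain why these groups behave as they do.

The three compounds do not show how far this tolerance runs: a longer chain such as hexyl, a more heavily branched tert-butyl group or a ring such as cyclohexyl or phenyl could keep the number low or could raise it. Going by these compounds, it also remains open whether an amine or a carboxylic acid at the end of the butyl chain would be accepted at this position.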